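Fluoro for chloro across two cores

The source may report more compounds than this note shows. Statements on the series, on what has been measured and on what is new or still open speak of the compounds shown alone.

Compound 1 `COc1ccc(Cl)c(-c2nnc3sc(-c4ccnc(Cl)c4)nn23)c1` and compound 3 `COc1ccc(Cl)c(-c2nnc3sc(-c4ccnc(F)c4)nn23)c1` share one core; compound 2 `Cc1occc1-c1nnc2sc(-c3ccnc(Cl)c3)nn12` and compound 4 `Cc1occc1-c1nnc2sc(-c3ccnc(F)c3)nn12` share the other. How the two cores differ is not broken down here. In a functional assay on the whole organism (strain Wistar Albino) for inhibition, with Rattus norvegicus as the target, read by paw edema, with a stated time of 1 h, at a dose of 20 mg/kg (a higher number here means more inhibition at the dose given (going by the name of the read-out), a lower number less inhibition), compound 1 gives 14.4%, compound 3 gives 18.5% and compound 2 gives 10.1%. Compound 2 stands nearest to compound 1 and furthest from compound 3, and both gaps lie within the scatter, so no order among the three measured compounds is claimed.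

The change from compound 1 to compound 3 is fluoro in place of chloro on an aromatic carbon. It made the step of a number 4.1 percentage points higher from compound 1 to compound 3 (within the scatter). The change from compound 2 to compound 4 reads (fluoro in place of chloro on an aromatic carbon), at a place described in the same words, so it is the same change on a different core. Compound 4 has not yet been measured in this assay.

Among the compounds with values here, a step of about the same size is expected from compound 2 to compound 4, namely a number 3.9 percentage points higher from compound 2 to compound 4 (within the scatter), because the one measured instance of this change is a number 4.1 percentage points higher from compound 1 to compound 3 (within the scatter) and stayed within the scatter. For compound 4 the estimate in this assay is 14%, with a range from 4% to 24%. This rests on a single measured pair and on compound 2 at 10.1% as the starting point; with the scatter of the read-out, the range is wide and no real change from compound 2 is asserted.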

Compound 4, a percentage reported as inhibition, in the whole organism at one dose (the size of the read-out at that dose, not a potency): 16.7%
Compound 4: the middle estimate sits 2.7 percentage points below what was measured, within the range that was stated.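

The new step in this assay is a number 6.6 percentage points higher from compound 2 to compound 4 (within the scatter), for 2-chloropyridin-4-yl to 2-fluoropyridin-4-yl. Set beside the earlier step, the same change on the other core gives no step that can be told apart from it: the same change on two cores in this assay, a number 4.1 percentage points higher (within the scatter) from compound 1 to compound 3 and a number 6.6 percentage points higher (within the scatter) from compound 2 to compound 4, 2.5 percentage points apart, within the scatter of two such steps

This shows that, on these two cores, the size of the step does not depend measurably on the core, and the change carries across them without any sign of a core-specific difference. It does not show that fluoro for chloro has a real effect in this assay on either core, since both steps lie within the scatter, and two pairs at a single dose and a single time say nothing about any other core in the series.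

The compounds shown hold only chloro and fluoro at this place on the ring, which leaves open whether an amine, a nitrile or a carboxylic acid there would give a reading clearly apart from these. Also open, on these data alone, is whether any group at this place would move the paw edema reading beyond the scatter on either core.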